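Dichlorophenyl replacing phenyl on the fluoroquinoline amide

The compounds below may be only part of what the source reports. "The series", "measured", "known", "first", "only" and "open" are said of these compounds alone.

The three measured compounds share one core and differ only by single substitutions. Compound 1 `COc1cc2c(Oc3ccc(NC(=O)c4cc(-c5ccccc5)nc5ccccc45)cc3F)ccnc2cc1OCCCN1CCCCC1` gives 110 nM in a functional assay on NCI-H460 cells (Homo sapiens) for cytotoxicity, read by MTT assay, with a stated time of 72 h; a higher number here means a weaker inhibitor, a lower number a stronger inhibitor. Compound 2 `COc1cc2c(Oc3ccc(NC(=O)c4cc(-c5ccc(F)cc5)nc5ccccc45)cc3F)ccnc2cc1OCCCN1CCCCC1` gives 21 nM, a step of a 5.2-fold lower number from compound 1 to compound 2 (0.72 log units; beyond the scatter). Compound 3 `COc1cc2c(Oc3ccc(NC(=O)c4cc(-c5ccccc5)nc5ccc(F)cc45)cc3F)ccnc2cc1OCCCN1CCCCC1` gives 32 nM, a step of a 3.4-fold lower number from compound 1 to compound 3 (0.54 log units; beyond the scatter). Compound 3 therefore stands second highest of the three numbers: its gap to compound 2 lies within the scatter, its gap to compound 1 beyond it.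

Compound 4 `COc1cc2c(Oc3ccc(NC(=O)c4cc(-c5ccc(Cl)cc5Cl)nc5ccc(F)cc45)cc3F)ccnc2cc1OCCCN1CCCCC1` carries the change (2,4-dichlorophenyl in place of phenyl on an aromatic carbon). Neither measured step exchanges the phenyl itself; both only add a fluoro at one aromatic carbon, and both lowered the number by a modest amount. Among the compounds with values here, the new change is larger than either and has no measured counterpart in this set, so the direction is uncertain; a modest step at most is expected, more likely downward than upward. Compound 4 is expected at 25 nM, within 8 nM to 80 nM, an expected step of a 1.3-fold lower number from compound 3 to compound 4 (0.11 log units; within the scatter).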

Compound 4, half-maximal inhibitory concentration: 310 nM
Compound 4: the middle estimate sits 12-fold (1.09 log units) below what was measured, outside the stated range (above it).
By their numbers in this assay, from the lowest: compounds 2 and 3 (each within the scatter of the next); then compound 1; then compound 4.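

In this assay, the aromatic carbon next to the ring nitrogen does not accept every change to its phenyl: 2,4-dichlorophenyl in place of phenyl gives a 9.7-fold higher number from compound 3 to compound 4 (0.99 log units; beyond the scatter). The step runs opposite to the fluoro step on the same phenyl, a 5.2-fold lower number from compound 1 to compound 2 (0.72 log units; beyond the scatter), so substitution on this ring does not lower the number in every case, although only these two steps bear on it. No supporting measurement accounts for the rise seen with the dichlorophenyl group.

Open, as far as these compounds go, is whether one chlorine alone would give the rise, or whether both are involved, and whether the step would hold on the core of compound 1. A single chlorine, a methoxy group or a dimethylamino group on that phenyl would show how far the outcome depends on the group itself.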